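The compounds below may be only part of what the source reports. "The series", "measured", "known", "first", "only" and "open" are said of these compounds alone.

Measured compounds in a functional assay on HeLa cells (Homo sapiens) for antiproliferative activity, read by CCK-8 assay, with a stated time of 72 h; a higher number here means a weaker inhibitor, a lower number a stronger inhibitor:
compound 1, `O=C(Nc1cccc(-c2oc3cc(-c4ccc(F)cc4)ccc3c(=O)c2O)c1)c1ccccc1F`, gives 5630 nM
compound 2, `O=C(Nc1cccc(-c2oc3cc(-c4ccc(F)cc4)ccc3c(=O)c2O)c1)c1cccc(F)c1`, gives 8780 nM
compound 3, `O=C(Nc1cccc(-c2oc3cc(-c4ccc(F)cc4)ccc3c(=O)c2O)c1)c1cc(F)cc(F)c1`, gives 3380 nM

Compound 2 holds the highest of the three numbers: a 1.6-fold higher number from compound 1 to compound 2 (0.19 log units; within the scatter) lies within the scatter, whereas a 2.6-fold lower number from compound 2 to compound 3 (0.41 log units; beyond the scatter) lies beyond it. Compound 4, `CCCc1ccc(C(=O)Nc2cccc(-c3oc4cc(-c5ccc(F)cc5)ccc4c(=O)c3O)c2)cc1`, differs from compound 2 by 4-propylphenyl in place of 3-fluorophenyl on a carbonyl carbon. The measured steps, a 1.6-fold higher number from compound 1 to compound 2 (0.19 log units; within the scatter), a 1.7-fold lower number from compound 1 to compound 3 (0.22 log units; within the scatter) and a 2.6-fold lower number from compound 2 to compound 3 (0.41 log units; beyond the scatter), all shift or add fluorine on the same ring; none removes fluorine or brings in a propyl chain, so they bear only loosely on this change and give no direction. The number for compound 4 is therefore expected close to that of compound 2, with a 1.3-fold lower number from compound 2 to compound 4 (0.10 log units; within the scatter) as the expected step, not beyond the scatter. Compound 4 is estimated at 7000 nM, in the range 2500 nM to 20000 nM.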

Compound 4, half-maximal inhibitory concentration: 8790 nM
Beside the measured number, compound 4's estimate is 1.3-fold (0.10 log units) below it; measured number inside the range.
By their numbers in this assay, from the lowest: compounds 3, 1, 2 and 4 (each within the scatter of the next, the first and the last beyond it).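

At this carbonyl carbon, 4-propylphenyl, which carries no fluorine, reads the same as 3-fluorophenyl (a 1.0-fold higher number from compound 2 to compound 4 (0.00 log units; within the scatter)) and as 2-fluorophenyl (a 1.6-fold higher number from compound 1 to compound 4 (0.19 log units; within the scatter)), with both steps within the scatter. Only 3,5-difluorophenyl stands apart from it (a 2.6-fold higher number from compound 3 to compound 4 (0.42 log units; beyond the scatter)), so fluorine on this ring is not needed to match the monofluoro compounds. No measured evidence accounts for these results.

As far as these compounds go, it remains open how an amine, a carboxylic acid or a longer chain at this position would read. It is also unclear whether the propyl chain would read the same elsewhere on the ring.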